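A few compounds are considered here, and "the series" means these few. Any claim that something is new, unique, unknown or untested is made for them only; others in the source may bear on it.

Compound 1 `O=C(O)CCCCC(CCSC(=O)c1ccccc1)SC(=O)c1ccccc1`: 1.09%
Compound 2 `O=C(CCCCC(S)CCS)Nc1ccc(Cl)cc1`: 1.06%
Compound 3 `O=C(CCCCC(S)CCS)Nc1ccc([N+](=O)[O-])cc1`: 1.88%

In a functional assay on Bel-7402 cells (Homo sapiens) for inhibition, read by MTT assay, with a stated time of 24 h, tested at 0.1 ug/mL (on this read-out lower numbers stand for less inhibition of growth and higher numbers for more inhibition of growth at the one concentration tested), compound 1 gives 1.09%, within the scatter of both compound 2 and compound 3. Compound 4 `O=C(CCCCC(CCSC(=O)c1ccccc1)SC(=O)c1ccccc1)Nc1ccc(Cl)cc1` differs from compound 1 by one change, (4-chlorophenyl)amino in place of hydroxy on a carbonyl carbon. Within the data shown here, no measured step covers this change. Among the measured compounds shown here, the only measured step, a number 0.8 percentage points higher from compound 2 to compound 3 (within the scatter), concerns nitro in place of chloro on an aromatic carbon and bears on it only loosely. Compound 2, which carries the same (4-chlorophenyl)amino group, reads 1.06%. No step beyond the scatter is therefore expected in this assay. For compound 4 the expected step is a number 0.9 percentage points higher from compound 1 to compound 4 (within the scatter). Compound 4 is expected at 2%, with an estimated range of 0% to 9%.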

Compound 4, percent growth inhibition at one concentration: 9.2%
For compound 4 the middle estimate is 7.2 percentage points below the measured one, and the stated range ends below it.
By their numbers in this assay, from the lowest: compounds 2, 1, 3 and 4 (each within the scatter of the next).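

In this assay, (4-chlorophenyl)amino in place of hydroxy on a carbonyl carbon gives a number 8.1 percentage points higher from compound 1 to compound 4 (within the scatter). Among these compounds, this is the first step read at this position, and it shows that the carboxy group can give way to (4-chlorophenyl)carbamoyl, with its six-membered aromatic ring, without a step beyond the scatter. Nothing shown gives a cause for this step.

From the compounds shown here alone, it remains open whether a benzylamino group or a methoxy group on the same carbonyl carbon would read beyond the scatter of compound 1.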